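Working notes: the step from compound 2 to compound 3

A few compounds are considered here, and "the series" means these few. Any claim that something is new, unique, unknown or untested is made for them only; others in the source may bear on it.

- compound 1 `Cc1n[nH]c2c1C(c1ccc(N(C)C)cc1)C(C(=O)NN)=C(N)N2` gives 42600 nM
- compound 2 `Cc1n[nH]c2c1C(c1ccc(N(C)C)cc1)C(C(=O)N/N=C/c1ccc(Cl)cc1)=C(N)N2` gives 25200 nM

In a functional assay on MCF7 cells (Homo sapiens) for cytotoxicity, read by MTT assay, with a stated time of 48 h (on this read-out lower numbers stand for stronger inhibition and higher numbers for weaker inhibition), compound 2 at 25200 nM stands within the scatter of compound 1 at 42600 nM and so holds no clear place in the pair. Compound 3 `Cc1n[nH]c2c1C(c1ccc(N(C)C)cc1)C(C(=O)N/N=C1/C(=O)Nc3ccccc31)=C(N)N2` departs from compound 2 by a group of 11 heavy atoms (8 carbon, 2 nitrogen, 1 oxygen; one five-membered non-aromatic ring with 1 hetero atom, one six-membered aromatic ring of carbon only) in place of a group of 9 heavy atoms (7 carbon, 1 nitrogen, 1 chlorine; one six-membered aromatic ring of carbon only), on an amide-type nitrogen and keeps the shared core. Within the data shown here, because a 1.7-fold lower number from compound 1 to compound 2 (0.23 log units; within the scatter) is the only measured step at this nitrogen and stays within the scatter, no step beyond the scatter is expected in this assay for the new group. One step is thin evidence, so the range stays wide. The estimated step is a 1.0-fold lower number from compound 2 to compound 3 (0.00 log units; within the scatter) in size. For compound 3 the expected value is 25000 nM with an estimated range from 9000 nM to 60000 nM in this read-out.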

Compound 3, half-maximal inhibitory concentration: 59100 nM
For compound 3 the middle estimate is 2.4-fold (0.37 log units) below the measured one; the measured number falls inside the stated range.
By their numbers in this assay, from the lowest: compounds 2, 1 and 3 (each within the scatter of the next, the first and the last beyond it).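

In this assay the amide-type nitrogen now gives its first step beyond the scatter, a modest one, when the group of 11 heavy atoms replaces the group of 9 heavy atoms: a 2.3-fold higher number from compound 2 to compound 3 (0.37 log units; beyond the scatter). Against the single nitrogen atom of compound 1 the same group stays within the scatter: a 1.4-fold higher number from compound 1 to compound 3 (0.14 log units; within the scatter). Nothing measured here bears on the origin of the gap between compound 2 and compound 3.

From the compounds shown here alone, it remains open whether a carboxylic acid or an amine at this nitrogen would move clearly away from compound 1.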